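Amide removal at the ring amine of the shared core

The source may report more compounds than this note shows. Statements on the series, on what has been measured and on what is new or still open speak of the compounds shown alone.

Compound 1 `O=C(Nc1nc(-c2ccccc2)nc2c1nnn2Cc1ccccc1)c1cccc([N+](=O)[O-])c1` gives 4850 nM in an assay on CHO cells for displacement of a labelled ligand from adenosine receptor A3 (Homo sapiens), read by scintillation counting; on this read-out lower numbers stand for stronger inhibition and higher numbers for weaker inhibition. Among the measured compounds shown here, compound 2 `O=C(Nc1nc(-c2ccccc2)nc2c1nnn2Cc1ccccc1)c1ccoc1` gives 1640 nM in this assay, the lowest of the two numbers at hand; the change a 3.0-fold lower number from compound 1 to compound 2 (0.47 log units; beyond the scatter) is the only measured step. Compound 3 `Nc1nc(-c2ccccc2)nc2c1nnn2Cc1ccccc1` differs from compound 2 by hydrogen in place of (furan-3-yl)carbonyl on a nitrogen on an aromatic ring. For the measured compounds named here, no measured step removes the whole acyl group, so the one step bears only indirectly on this change; a modest move toward weaker inhibition, a 3.0-fold higher number from compound 2 to compound 3 (0.48 log units; beyond the scatter), is expected. For compound 3 the estimated value in this assay is 5000 nM, with a range from 1500 nM to 20000 nM.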

Compound 3, inhibition constant: 4220 nM
For compound 3 the middle estimate is 1.2-fold (0.07 log units) above the measured one; the measured number falls inside the stated range.
By their numbers in this assay, from the lowest: compound 2; then compounds 3 and 1 (each within the scatter of the next).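

Removing the acyl group from this ring nitrogen gives a 2.6-fold higher number from compound 2 to compound 3 (0.41 log units; beyond the scatter) in this assay and so shows that the (furan-3-yl)carbonyl amide keeps a modest edge over the free amino group. The (3-nitrophenyl)carbonyl amide keeps no such edge, with a 1.1-fold lower number from compound 1 to compound 3 (0.06 log units; within the scatter) and therefore no separation from the free amine, so the outcome of acylation at this position depends on the acyl group attached. Nothing available accounts for this difference between the two amides.

Still open, from the compounds shown here alone, is how an acetyl group, a longer alkanoyl chain or an unsubstituted benzoyl group on this nitrogen would compare with the (furan-3-yl)carbonyl amide.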